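Swapping a pyridine for a cyanophenyl: expected cytotoxicity

The source may report more compounds than this note shows. Statements on the series, on what has been measured and on what is new or still open speak of the compounds shown alone.

Compound 1, `CCc1nc(N)nc(N)c1C#CC(C)c1ccc(-c2ccncc2)cc1OC`, was tested in an ADME assay on MCF10 cells (Homo sapiens) for cytotoxicity (a higher number here means a weaker inhibitor, a lower number a stronger inhibitor), and gives 216000 nM. Compound 2, `CCc1nc(N)nc(N)c1C#CC(C)c1ccc(-c2ccc(O)cc2)cc1OC`, gives 148000 nM in this assay, and the change a 1.5-fold lower number from compound 1 to compound 2 (0.16 log units; within the scatter) is within the scatter, so the two numbers cannot be told apart; compound 3, `CCc1nc(N)nc(N)c1C#CC(C)c1ccc(-c2ccc(C)cc2)cc1OC`, gives "not determined" (no result reported) in this assay, that is, no result, so compound 1 stands with just one measured companion that matches it. Compound 4, `CCc1nc(N)nc(N)c1C#CC(C)c1ccc(-c2ccc(C#N)cc2)cc1OC`, differs from compound 1 by 4-cyanophenyl in place of pyridin-4-yl on an aromatic carbon. Among the measured compounds shown here, the only measured step that touches this part of the molecule is the one from compound 1 to compound 2, where a 4-hydroxyphenyl entered in the same place and the number did not move beyond the scatter. A second group entering on that same aromatic carbon is therefore expected to leave this assay largely unchanged, with no step beyond the scatter predicted: a 1.1-fold lower number from compound 1 to compound 4 (0.03 log units; within the scatter). Compound 4 is thus expected to give about 200000 nM, within a range from 80000 nM to 500000 nM.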

Compound 4, half-maximal inhibitory concentration: 50000 nM
Estimate against measurement, compound 4: 4.0-fold (0.60 log units) above; the measured number lies below the stated range.
By their numbers in this assay, from the lowest: compound 4; then compounds 2 and 1 (each within the scatter of the next).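

This position is less indifferent than the earlier pair suggested. In this assay, 4-cyanophenyl in place of pyridin-4-yl gives a 4.3-fold lower number from compound 1 to compound 4 (0.64 log units; beyond the scatter), and cyano in place of hydroxy on the same phenyl ring gives a 3.0-fold lower number from compound 2 to compound 4 (0.47 log units; beyond the scatter), so both comparisons set compound 4 apart, although only modestly, while compound 1 and compound 2 remain within the scatter of each other. No measurement shown here explains this difference.

The compounds shown leave open whether the lower number is specific to the nitrile, with only cyano and hydroxy available for comparison on this phenyl ring. An amine or a carboxylic acid in the same place would show whether other groups also lower the number in this assay or leave it within the scatter of compound 2.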